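This account rests on a few compounds, and the source may have more. Where it says the series, first, only, none or still open, it means among the compounds named here.

Measured so far:
- compound 1 `CC(C)=CCC/C(C)=C/CC/C(C)=C/CSC[C@H](NC(=O)CCCCCN1CCN(C)CC1)C(=O)NC1CCCCCC1`: 6200 nM
- compound 2 `CC(C)=CCC/C(C)=C/CC/C(C)=C/CSC[C@H](NC(=O)CCCCCN1CCCC1)C(=O)NC1CCCCC1`: 12700 nM

Not yet measured:
- compound 3 `CC(C)=CCC/C(C)=C/CC/C(C)=C/CSC[C@H](NC(=O)CCCCCN1CCCC1)C(=O)NC1CCCC1`

In a functional assay on BXPC-3 cells (Homo sapiens) for cytotoxicity, read by fluorescence, with a stated time of 48 h (on this read-out lower numbers stand for an effect already at smaller amounts and higher numbers for an effect only at larger amounts of compound), compound 2 gives 12700 nM, the higher of the two numbers, and compound 1 gives 6200 nM, a gap beyond the scatter. Compound 3 has cyclopentyl in place of cyclohexyl on an amide-type nitrogen. Going by the values given here, no measured pair isolates a change at one place, so the expectation rests on compound 2 at 12700 nM. No step beyond the scatter is expected in this assay: the estimated step is a 1.1-fold higher number from compound 2 to compound 3 (0.04 log units; within the scatter). The estimate for compound 3 is 14000 nM, with an expected range of 7000 nM to 28000 nM.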

Compound 3, half-maximal effective concentration: 6800 nM
For compound 3 the middle estimate is 2.1-fold (0.31 log units) above the measured one; measured number below the stated range.
By their numbers in this assay, from the lowest: compounds 1, 3 and 2 (each within the scatter of the next, the first and the last beyond it).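

Cyclopentyl in place of cyclohexyl on an amide-type nitrogen gives the first single-place step of the series in this assay, namely a 1.9-fold lower number from compound 2 to compound 3 (0.27 log units; within the scatter), so at this position the two ring sizes cannot be told apart in this read-out. No evidence on a cause of this step is available.

Compound 1 differs from compound 2 and compound 3 in more than one place, so it does not isolate this position. Open, as far as these compounds go, is whether an open-chain group such as isopropyl, or a ring carrying an amine, on this nitrogen would stay within the same range.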